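The source may hold more compounds than are shown below. What is called first, only, known or untested is meant among the compounds shown, and "the series" means these compounds.

Measured compounds:
compound 1 `O=C1CS/C(=N/Nc2nncc3ccccc23)N1c1ccccc1`, 44 nM
compound 2 `N#Cc1ccc(Nc2nncc3ccccc23)cc1`, 4.3 nM

In a functional assay on OVCAR-3 cells (Homo sapiens) for antiproliferative activity, read by sulforhodamine B assay, with a stated time of 72 h (on this read-out lower numbers stand for stronger inhibition and higher numbers for weaker inhibition), compound 1 gives the higher of the two numbers, while compound 2 gives a number that lies below it by more than the scatter. Compound 3 `CCN1C(=O)CS/C1=N/Nc1nncc2ccccc12` differs from compound 1 in one place: ethyl in place of phenyl on an amide-type nitrogen in a ring. Going by the values given here, no measured pair shows this change, so its size is uncertain; a small step toward a higher number is expected for compound 3, with a 1.8-fold higher number from compound 1 to compound 3 (0.26 log units; within the scatter) as the expected step, possibly within the scatter. Compound 3 is therefore estimated at 80 nM, with a range from 25 nM to 300 nM.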

Compound 3, half-maximal inhibitory concentration: 55 nM
For compound 3 the middle estimate is 1.5-fold (0.16 log units) above the measured one, within the range that was stated.
By their numbers in this assay, from the lowest: compound 2; then compounds 1 and 3 (each within the scatter of the next).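

In this assay, ethyl in place of phenyl on the amide-type nitrogen in the ring gives a 1.3-fold higher number from compound 1 to compound 3 (0.10 log units; within the scatter), so the two groups cannot be told apart here. Going by these compounds alone, this is the first sign that a six-membered aromatic ring of carbon is not needed on this nitrogen for a number in this range, and that the smaller ethyl serves as well. Nothing available explains this tolerance. The compounds shown leave open how a longer chain, a benzyl group or a carboxylic acid on this nitrogen would read.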